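A few compounds are considered here, and "the series" means these few. Any claim that something is new, unique, unknown or untested is made for them only; others in the source may bear on it.

Compound 1, `O=C(Nc1nc(-c2ccccc2Cl)cs1)c1ccccc1`: 15000 nM in a functional assay on MDA-MB-231 cells (Homo sapiens), read by microscopy and transwell migration, with a stated time of 24 h; a lower number here means a stronger inhibitor, a higher number a weaker inhibitor.
Compound 2, `O=C(Nc1nc(-c2cccc(Br)c2)cs1)c1ccccc1`: 10000 nM in this assay.
Compound 3, `Cn1c(-c2ccccc2Cl)cs/c1=N\C(=O)c1ccccc1`: 268 nM in this assay.

Compound 2 differs from compound 1 in a single spot: 3-bromophenyl in place of 2-chlorophenyl on an aromatic carbon. That change gave a 1.5-fold lower number from compound 1 to compound 2 (0.18 log units; within the scatter). Compound 3 is built on a different core; the difference between the two cores is not broken down here, yet compound 3 gives a markedly lower number than compound 1 or compound 2. Compound 4, `Cn1c(-c2cccc(Br)c2)cs/c1=N\C(=O)c1ccccc1`, is not yet measured. It differs from compound 3 by the same kind of change: 3-bromophenyl in place of 2-chlorophenyl on an aromatic carbon. The surroundings are not identical, though: in compound 1 the changed carbon is two ring bonds from the ring atom that bears a group of 9 heavy atoms, while in compound 3 it is next to the ring atom that bears a methyl group. In this assay the step from compound 3 to compound 4 is expected to be a 1.3-fold lower number from compound 3 to compound 4 (0.13 log units; within the scatter) because a 1.5-fold lower number from compound 1 to compound 2 (0.18 log units; within the scatter) stayed within the scatter. Compound 4 is therefore estimated at 200 nM, within a range of 80 nM to 500 nM.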

Compound 4, half-maximal inhibitory concentration: 302 nM
The estimate for compound 4 lay 1.5-fold (0.18 log units) below the measured number; the measured number falls inside the stated range.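

In this assay, putting 3-bromophenyl in place of 2-chlorophenyl on the core of compound 3 gave a 1.1-fold higher number from compound 3 to compound 4 (0.05 log units; within the scatter). Set beside the earlier step, the same change reads alike on the two cores: the same change on two cores in this assay, a 1.5-fold lower number (0.18 log units; within the scatter) from compound 1 to compound 2 and a 1.1-fold higher number (0.05 log units; within the scatter) from compound 3 to compound 4, 1.7-fold (0.23 log units) apart, within the scatter of two such steps. This shows that, for this one swap, a step within the scatter on one core was matched by a step within the scatter on the other; it does not show that a change with a large step would carry across in the same way.

The compounds shown leave open whether a phenyl bearing an amine or a carboxylic acid in place of the halogen would read alike on both cores. They also leave open whether a longer chain in place of the methyl group would keep numbers like those of compound 3 and compound 4.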